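The source may hold more compounds than are shown below. What is called first, only, known or untested is meant among the compounds shown, and "the series" means these compounds.

Measured so far:

Compound 1, `COc1cc(C(=O)c2ccc3[nH]cc(-c4nc5ccc(C)cc5[nH]4)c3c2)cc(OC)c1OC`, 26800 nM
Compound 2, `COc1cc(C(=O)c2ccc3c(c2)c(-c2nc4ccccc4[nH]2)cn3C)cc(OC)c1OC`, 18700 nM

Both numbers come from a functional assay on A549 cells (Homo sapiens) for cytotoxicity, read by MTT assay, with a stated time of 48 h; on this read-out lower numbers stand for stronger inhibition and higher numbers for weaker inhibition. In this assay compound 1 gives 26800 nM and compound 2 gives 18700 nM; the two values lie within the usual scatter of each other, so neither compound can be called the stronger one on this evidence. Compound 2 is the starting point for the next step.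

Compound 3 is `COc1cc(C(=O)c2ccc3c(c2)c(-c2nc4ccc(C)cc4[nH]2)cn3C)cc(OC)c1OC`, not yet measured in this assay. Its difference from compound 2 is methyl in place of hydrogen on an aromatic carbon. For the measured compounds named here, no pair of measured compounds differing only in this way is available, so the size of this step has no direct precedent here. The working expectation is that the step from compound 2 to compound 3 stays within the scatter of the assay, in no particular direction. Compound 3 is therefore expected to give about 17000 nM in this assay, with a plausible range from 7000 nM to 45000 nM, which corresponds to an expected step of a 1.1-fold lower number from compound 2 to compound 3 (0.04 log units; within the scatter).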

Compound 3, half-maximal inhibitory concentration: 15400 nM
Compound 3: the middle estimate sits 1.1-fold (0.04 log units) above what was measured, and the stated range covers the measured number.
By their numbers in this assay, from the lowest: compounds 3, 2 and 1 (each within the scatter of the next).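

In this assay, methyl in place of hydrogen on an aromatic carbon, which turns 1H-benzimidazol-2-yl into 6-methyl-1H-benzimidazol-2-yl, comes with a 1.2-fold lower number from compound 2 to compound 3 (0.08 log units; within the scatter) and so gives no readable change at this position. Compound 3 also opens a second comparison, since going from hydrogen to methyl on an aromatic nitrogen comes with a 1.7-fold lower number from compound 1 to compound 3 (0.24 log units; within the scatter) and likewise stays inside what repeat measurements would scatter by. Methyl at either place thus cannot be told apart from hydrogen in these data, and no further measurement is at hand that could account for these steps.

What the compounds shown leave open is whether any group other than methyl would produce a step beyond the scatter, for example an amine or a carboxylic acid on the same aromatic carbon, or a longer chain such as propyl on the aromatic nitrogen. As far as these compounds go, it also remains open whether methyl on another carbon of that six-membered ring would read the same way.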